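This account rests on a few compounds, and the source may have more. Where it says the series, first, only, none or still open, it means among the compounds named here.

Compound 2 (`O=C(Cn1cc(C(=O)O)nn1)NCc1ccccc1`) is reported in an ADME assay on cells (spleen, Mus musculus, strain C57BL/6) for inhibition, read by flow cytometry and propidium iodide staining, with a stated time of 24 h, at 37 degrees C (on this read-out higher numbers stand for an effect only at larger amounts of compound and lower numbers for an effect already at smaller amounts), as "non-toxic" (no number reported) and so has no place on the numerical scale. Compound 4 (`Nc1cccc(-c2cn(CC(=O)NCc3ccccc3)nn2)c1`) differs from it by 3-aminophenyl in place of carboxy on an aromatic carbon with 3-aminophenyl in place of carboxy on an aromatic carbon. Among the measured compounds shown here, compound 1 (`O=C(Cn1cc(CO)nn1)NCc1ccccc1`) gives 490 uM as the only true number in this small set. Compound 3 (`CC(C)(C)OC(=O)NCc1cn(CC(=O)NCc2ccccc2)nn1`) gives > 2000 uM as a limit of the assay and not a number. For the measured compounds named here, the only measured step is an at least 4.0-fold higher number from compound 1 to compound 3 (0.61 log units; beyond the scatter) and it involves other groups, so it offers just a rough size. A step of about that size toward a lower number is expected because compound 2 is reported as "non-toxic" (no number reported) and that leaves room mainly downward. Compound 4 is expected at about 400 uM with an estimated range from 80 uM to 2000 uM in this assay for now.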

Compound 4, concentration for half-maximal effect: 800 uM
For compound 4 the middle estimate is 2.0-fold (0.30 log units) below the measured one; measured number inside the range.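

Compound 4 shows that this aromatic carbon can carry a whole 3-aminophenyl group, with its six-membered aromatic ring, and still give a true number in this assay. Replacing hydroxymethyl with 3-aminophenyl gives a 1.6-fold higher number from compound 1 to compound 4 (0.21 log units; within the scatter), so these two values cannot be told apart. Compound 3 remains a limit of the assay: the limit of > 2000 uM in this assay, at which 1 of the 4 values shown sits.

From the compounds shown here alone, it remains open whether the ring or its amine matters more at this position. A plain phenyl group would separate the two, and a longer chain ending in an amine would test whether the ring is needed at all.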